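The source may report more compounds than this note shows. Statements on the series, on what has been measured and on what is new or still open speak of the compounds shown alone.

Measured so far:
- compound 1 `CC(C)c1cccc(C(C)C)c1OC(=O)NS(=O)(=O)N1CCc2ccccc21` gives 43000 nM in an assay on liver for inhibition of sterol O-acyltransferase 1 (Rattus norvegicus), using microsomes; on this read-out lower numbers stand for stronger inhibition and higher numbers for weaker inhibition
- compound 2 `CC(C)c1cccc(C(C)C)c1OC(=O)NS(=O)(=O)N(C(C)C)C(C)C` gives 15000 nM in this assay

Compound 2 has the lowest number of the two measured compounds; its nearest neighbour is compound 1, and the step of a 2.9-fold lower number from compound 1 to compound 2 (0.46 log units; beyond the scatter) lies beyond the scatter. Compound 3 `CCCCCCNS(=O)(=O)NC(=O)Oc1c(C(C)C)cccc1C(C)C` is not yet measured. It differs from compound 2 in one place: hexylamino in place of diisopropylamino on a sulfonyl sulfur. Among the measured compounds shown here, only one measured step touches this position on the sulfonyl sulfur, namely a 2.9-fold lower number from compound 1 to compound 2 (0.46 log units; beyond the scatter), and that step swapped a ring for a branched chain rather than one chain for another. For the measured compounds named here, no measured pair shows what a linear hexylamino does in place of a branched diisopropylamino here. The expectation for this assay is therefore a step of no clear direction, with compound 3 expected to land near compound 2, a 1.3-fold higher number from compound 2 to compound 3 (0.12 log units; within the scatter). The estimate for compound 3 is 20000 nM, between 5000 nM and 70000 nM.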

Compound 3, half-maximal inhibitory concentration: 21000 nM
Beside the measured number, compound 3's estimate is 1.1-fold (0.02 log units) below it, within the range that was stated.
By their numbers in this assay, from the lowest: compounds 2 and 3 (each within the scatter of the next); then compound 1.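

In this assay, among the compounds shown here, compound 3 gives the first direct comparison of a linear chain with a branched chain on the sulfonyl sulfur: a 1.4-fold higher number from compound 2 to compound 3 (0.15 log units; within the scatter). Hexylamino in place of diisopropylamino therefore adds one hydrogen-bond donor, as counted from the structures, without a step beyond the scatter. Hexylamino in place of 2,3-dihydro-1H-indol-1-yl gives a 2.0-fold lower number from compound 1 to compound 3 (0.31 log units; beyond the scatter), the same direction as a 2.9-fold lower number from compound 1 to compound 2 (0.46 log units; beyond the scatter), so both open-chain groups shown have lower numbers than the ring-bearing compound 1, though no measurement shown explains why.

The compounds shown leave open how a longer chain such as dodecylamino, or a hexylamino chain carrying a carboxylic acid, would read in this assay. They also leave open whether any other amine on the sulfonyl sulfur could give a much lower number.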